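Fluoro in place of chloro: working notes on compound 4

A few compounds are considered here, and "the series" means these few. Any claim that something is new, unique, unknown or untested is made for them only; others in the source may bear on it.

Measured in a functional assay on NALM-6 cells (Homo sapiens) for cytotoxicity, read by luminescence and CellTiter-Glo, with a stated time of 3 days; a higher number here means a weaker inhibitor, a lower number a stronger inhibitor:
- compound 1 `O=C(Nc1cc(C(F)(F)F)cc(C(F)(F)F)c1)c1ccc(-c2ccccc2)cc1O`: 1580 nM
- compound 2 `N#Cc1ccc(NC(=O)c2ccc3cccnc3c2O)c(F)c1`: 370 nM
- compound 3 `O=C(Nc1ccc(C(F)(F)F)cc1)c1ccc(Cl)cc1O`: 1180 nM

Going by the values given here, three values are too few to support a pattern, and the measured compounds include no pair that differs in one place. Of these three, compound 3 (1180 nM) lies within the scatter of compound 1 (1580 nM). Compound 2 (370 nM) gives a lower number than compound 3, and that gap lies beyond the scatter, so compound 3 stands at the weaker end of this small set.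

The next compound for this assay is compound 4 `O=C(Nc1ccc(C(F)(F)F)cc1)c1ccc(F)cc1O`, which carries fluoro in place of chloro on an aromatic carbon, meta to a hydroxy group and para to a large group fluoro in place of chloro on an aromatic carbon and is otherwise the same as compound 3. Among the compounds with values here, no measured step shows what this exchange does, so the expectation starts from compound 3 (1180 nM) alone. A small shift toward a higher number is expected in this assay, but none beyond the scatter. The estimated step is a 1.4-fold higher number from compound 3 to compound 4 (0.16 log units; within the scatter) and carries wide uncertainty.

For compound 4 the expected value is 1700 nM, with an estimated range from 700 nM to 4000 nM.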

Compound 4, half-maximal inhibitory concentration: 1530 nM
Compound 4: middle estimate off by 1.1-fold (0.05 log units), on the high side; the measured number falls inside the stated range.
By their numbers in this assay, from the lowest: compound 2; then compounds 3, 4 and 1 (each within the scatter of the next).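

Going by these compounds alone, the exchange of chloro for fluoro gives the first single-place step: in this assay it is a 1.3-fold higher number from compound 3 to compound 4 (0.11 log units; within the scatter), and this step lies within the scatter. Within the data shown here, on an aromatic carbon, meta to a hydroxy group and para to a large group, chloro and fluoro therefore cannot be told apart by this read-out, at least on the shared core of this pair, and the earlier compounds offered no such direct reading at any place. Nothing on hand accounts for this outcome.

On these data alone, what remains open is whether this place is as undemanding for groups other than these two, since a single exchange between two halogens says little about hydrogen, methoxy, an amine or a carboxylic acid on the same carbon. The hydroxy group and the trifluoromethyl group of this pair also stay unexplored as single changes, so how much each contributes to the number in this assay cannot be read from the compounds shown.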